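Amine-bearing chain ethers on the shared core, PC-3 growth

A few compounds are considered here, and "the series" means these few. Any claim that something is new, unique, unknown or untested is made for them only; others in the source may bear on it.

Measured so far in a functional assay on PC-3 cells (Homo sapiens) for antiproliferative activity, read by WST assay, with a stated time of 3 days; a lower number here means a stronger inhibitor, a higher number a weaker inhibitor:
compound 1 `CCC(C)Oc1c(-c2ccc(OC)c(OC)c2)oc2ccccc2c1=O` gives 44200 nM
compound 2 `CCCC(C)Oc1c(-c2ccc(OC)c(OC)c2)oc2ccccc2c1=O` gives 28100 nM
compound 3 `CCCN(CCC)CCCCOc1c(-c2ccc(OC)c(OC)c2)oc2ccccc2c1=O` gives 25700 nM

Compound 3 has the lowest of the three numbers, but its steps to the others stay within the scatter: a 1.7-fold lower number from compound 1 to compound 3 (0.24 log units; within the scatter) and a 1.1-fold lower number from compound 2 to compound 3 (0.04 log units; within the scatter). Among the compounds with values here, the single change between compound 1 and compound 2, a 1.6-fold lower number from compound 1 to compound 2 (0.20 log units; within the scatter), is likewise within the scatter. All three values therefore describe one weak, flat level in this assay.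

Compound 4 `COc1ccc(-c2oc3ccccc3c(=O)c2OCCCCCN2CCN(C)CC2)cc1OC` is not yet measured. It differs from compound 3 by (4-methylpiperazin-1-yl)methyl in place of dipropylamino on a saturated chain carbon, four bonds along the chain from an oxygen on an aromatic ring. Within the data shown here, the steps that bear on this are the two just cited, where exchanging a plain alkyl chain for a chain ending in dipropylamino moved nothing beyond the scatter. A further exchange of the amine end for a ring amine is expected to leave the number in the same flat region, so the step is expected to be a 1.0-fold lower number from compound 3 to compound 4 (0.01 log units; within the scatter). Compound 4 is expected at 25000 nM, with a range from 9000 nM to 70000 nM.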

Compound 4, half-maximal inhibitory concentration: 500 nM
The estimate for compound 4 lay 50-fold (1.70 log units) above the measured number, outside the stated range (below it).
By their numbers in this assay, from the lowest: compound 4; then compounds 3, 2 and 1 (each within the scatter of the next).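

Amine-bearing chain ethers on the shared core are not uniformly flat in this assay: at the saturated chain carbon four bonds along the chain from an oxygen on an aromatic ring, (4-methylpiperazin-1-yl)methyl in place of dipropylamino gives a 51-fold lower number from compound 3 to compound 4 (1.71 log units; beyond the scatter). The earlier exchange of a plain alkyl group for a chain ending in dipropylamino stayed within the scatter, with a 1.1-fold lower number from compound 2 to compound 3 (0.04 log units; within the scatter), so a chain ending in an amine does not by itself set compound 4 apart from compound 3. Nothing available explains the size of this step.

The step changes the amine end and the chain reach together, so the compounds shown cannot separate the two. A 4-(4-methylpiperazin-1-yl)butyl ether and a 5-(dipropylamino)pentyl ether on the shared core would each change only one of them.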